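A few compounds are considered here, and "the series" means these few. Any claim that something is new, unique, unknown or untested is made for them only; others in the source may bear on it.

Compound 1 (`O=C(CSc1nccn1-c1ccc(Cl)cc1)Nc1ccccc1Br`) and compound 2 (`Cc1ccc(-n2ccnc2SCC(=O)Nc2ccccc2Br)cc1`) share one core; compound 3 (`O=C(CSc1nccn1-c1ccc(Cl)cc1)Nc1ccccc1Cl`) is still to be measured. In an ADME assay on MT4 cells (Homo sapiens) for cytotoxicity, read by MTT assay (a lower number here means that less compound is tolerated, a higher number that more compound is tolerated), compound 1 gives only a limit, > 300000 nM, so its true position is open, and it stands at the limit of > 300000 nM in this assay, at which 1 of the 2 values shown sits. Compound 2 gives 39300 nM in this assay. Among the measured compounds shown here, the one measured step, an at least 7.6-fold lower number from compound 1 to compound 2 (0.88 log units; beyond the scatter), alters the other aromatic ring and does not bear on (chloro in place of bromo on an aromatic carbon). For the measured compounds named here, with no measured step speaking to this change, no step beyond the scatter is expected, a number no higher from compound 1 to compound 3 (the limit leaves the size open). Compound 3 is therefore estimated at 300000 nM, between 100000 nM and 600000 nM, most probably again reported only as a limit.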

Compound 3, half-maximal cytotoxic concentration: > 330000 nM
Compound 3 gave a limit, no number (the forecaster's own chance of this, stated with the estimate: 70%); middle value at least 1.1-fold (0.04 log units) from the limit.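

Among the compounds shown here, compound 1 and compound 3 both end at limits in this assay, so no step between them can be read. Going by these compounds, whether chloro in place of bromo on an aromatic carbon shifts this read-out at all remains open.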